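The source may hold more compounds than are shown below. What is called first, only, known or untested is meant among the compounds shown, and "the series" means these compounds.

Series notes, antiproliferative run.

Compound 1 `CN(C(=O)CCc1ccccc1)c1ccc2[nH]c(-c3n[nH]c4ccccc34)cc2n1`: 7380 nM
Compound 2 `CN(c1ccc2[nH]c(-c3n[nH]c4ccccc34)cc2n1)S(=O)(=O)c1ccccc1`: 2400 nM

Both numbers come from a functional assay on KB cells (Homo sapiens) for antiproliferative activity, read by MTT assay, with a stated time of 72 h; on this read-out lower numbers stand for stronger inhibition and higher numbers for weaker inhibition. Within the data shown here, compound 2 carries the lowest of the two values; the nearest is compound 1, separated by the single step to hand, a 3.1-fold lower number from compound 1 to compound 2 (0.49 log units; beyond the scatter), which goes with phenylsulfonyl in place of phenethylcarbonyl on a nitrogen on an aromatic ring.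

Compound 3 `Cc1ccc(S(=O)(=O)N(C)c2ccc3[nH]c(-c4n[nH]c5ccccc45)cc3n2)cc1` differs from compound 2 by methyl in place of hydrogen on an aromatic carbon, on an aromatic carbon of the six-membered carbon ring, para to a large group. Among the measured compounds shown here, no measured step covers a change of this kind; the step from compound 1 to compound 2 concerns the group on the nitrogen and does not bear on it. Compound 3 is therefore expected to stay close to compound 2, with no step beyond the scatter, a 1.2-fold lower number from compound 2 to compound 3 (0.08 log units; within the scatter). Compound 3 is estimated at 2000 nM, within 900 nM to 5000 nM.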

Compound 3, half-maximal inhibitory concentration: 9500 nM
The estimate for compound 3 lay 4.8-fold (0.68 log units) below the measured number; measured number above the stated range.
By their numbers in this assay, from the lowest: compound 2; then compounds 1 and 3 (each within the scatter of the next).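

In this assay, the aromatic carbon para to a large group on the phenylsulfonyl ring proves sensitive to a small change: phenylsulfonyl to (4-methylphenyl)sulfonyl, which adds one carbon, gives a 4.0-fold higher number from compound 2 to compound 3 (0.60 log units; beyond the scatter) and is beyond the scatter. The advantage of phenylsulfonyl over phenethylcarbonyl does not carry over to the methylated ring, since a 1.3-fold higher number from compound 1 to compound 3 (0.11 log units; within the scatter) leaves (4-methylphenyl)sulfonyl and phenethylcarbonyl on the nitrogen indistinguishable in this series. Nothing available accounts for the effect of the methyl group.

On these data alone, whether the rise is particular to methyl remains open, as a chlorine atom or a methoxy group at the same carbon would show. Also open, as far as these compounds go, is whether an amine or a carboxylic acid there would move the number in the same direction, or whether a longer alkyl chain would extend the change.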